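The source may hold more compounds than are shown below. What is called first, only, known or untested is meant among the compounds shown, and "the series" means these compounds.

The compounds here share one core, and the question is how much of each a living cell tolerates. In an ADME assay on Vero cells (Chlorocebus sabaeus) for cytotoxicity (a higher number here means that more compound is tolerated, a lower number that less compound is tolerated), compound 1 `CCC(=O)Nc1ccc(-c2nc3cc(C(F)(F)F)ccc3n2C2CCCCC2)cc1` gives > 100000 nM, which is a limit of the assay rather than a measured number. Compound 3 `CCC(=O)Nc1ccc(-c2nc3cc(C(F)(F)F)ccc3n2C)cc1` gives > 100000 nM in this assay, again a limit. Compound 2 `CCN(CC)CC(=O)Nc1ccc(-c2nc3cc(C(F)(F)F)ccc3n2C)cc1` gives a number, 90000 nM. Two measured steps connect these three. Changing methyl in place of cyclohexyl on an aromatic nitrogen gives a step that the two limits leave unreadable from compound 1 to compound 3. Changing methyl in place of diethylamino on a saturated chain carbon bound to a carbonyl carbon gives an at least 1.1-fold higher number from compound 2 to compound 3 (0.04 log units; that floor lies within the scatter). Compound 1 thus sits at the limit of > 100000 nM in this assay, at which 2 of the 3 values shown sit, and its standing is known only as a limit.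

Compound 4 `O=[N+]([O-])c1ccc(-c2nc3cc(C(F)(F)F)ccc3n2C2CCCCC2)cc1` differs from compound 1 by nitro in place of propanoylamino on an aromatic carbon. Neither measured step alters this group; both keep the propanoylamino group and change other parts of the core. Going by the values given here, no measured step therefore bears directly on this change, and what is expected rests on compound 1 alone. Compound 4 is expected to show an at least 1.2-fold lower number from compound 1 to compound 4 (0.09 log units; that floor lies within the scatter), a step not readable beyond the scatter from a limit. Compound 4 is estimated at 80000 nM, within a range from 30000 nM to 200000 nM.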

Compound 4, half-maximal cytotoxic concentration: > 100000 nM
Compound 4: only a limit was reported (the forecaster's own chance of this, stated with the estimate: 45%); middle value at least 1.2-fold (0.09 log units) away from the limit.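

In this assay compound 4 gives > 100000 nM, which is a limit of the assay and not a number. No step can be read between compound 1 and compound 4, because both stand at the same limit: the limit of > 100000 nM in this assay, at which 3 of the 4 values shown sit. The compounds shown leave open how much cells tolerate nitro compared with propanoylamino on this core.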